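Following a Fluoro-to-Methoxy Swap in a Cytotoxicity Series

The source may report more compounds than this note shows. Statements on the series, on what has been measured and on what is new or still open speak of the compounds shown alone.

Compound 1 `COc1ccc2c(/C=C(\C#N)C(=O)c3c[nH]c4cc(F)ccc34)c[nH]c2c1`: 10300 nM
Compound 2 `N#C/C(=C\c1cn(Cc2ccc(Cl)cc2)c2ccccc12)C(=O)c1c[nH]c2cc(F)ccc12`: > 50000 nM (a limit)

Both results come from a functional assay on A549 cells (Homo sapiens) for cytotoxicity, read by WST assay, with a stated time of 24 h; on this read-out higher numbers stand for weaker inhibition and lower numbers for stronger inhibition. Compound 1 gives a number there, 10300 nM, while the second result is not a number. Compound 2 reads > 50000 nM, which is a limit of this assay. Compound 2 therefore stands at the limit of > 50000 nM in this assay, at which 1 of the 2 values shown sits.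

The next compound, compound 3 `COc1ccc2c(C(=O)/C(C#N)=C/c3cn(Cc4ccc(Cl)cc4)c4ccccc34)c[nH]c2c1`, departs from compound 2 in one place: methoxy in place of fluoro on an aromatic carbon. This puts methoxy in place of fluoro on an aromatic carbon, so that 6-fluoro-1H-indol-3-yl becomes 6-methoxy-1H-indol-3-yl.

Among the measured compounds shown here, no measured pair shows this change on its own, so any expectation rests on thin ground. Little movement is expected in this assay, perhaps a small shift towards stronger inhibition, and another limit would be no surprise. The expected change is an at least 1.1-fold lower number from compound 2 to compound 3 (0.04 log units; that floor lies within the scatter). For compound 3 the estimated value is 45000 nM, with an expected range of 18000 nM to 100000 nM.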

Compound 3, half-maximal inhibitory concentration: > 50000 nM
Compound 3 was reported as a limit (the forecaster's own chance of this, stated with the estimate: 55%); at least 1.1-fold (0.04 log units) between middle value and limit.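

In this assay compound 3 reads > 50000 nM, which is a limit and not a number. Compound 2 also stands at a limit, so no step can be read between compound 2 and compound 3. From the compounds shown here alone, whether methoxy in place of fluoro on an aromatic carbon changes the result in this assay remains open.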